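The source may report more compounds than this note shows. Statements on the series, on what has been measured and on what is new or still open speak of the compounds shown alone.

Measured in a functional assay on K562 cells (Homo sapiens), read by MTT assay, with a stated time of 72 h; a higher number here means a weaker inhibitor, a lower number a stronger inhibitor:
- Compound 1 `CSc1ncnc2c1c(-c1ccsc1)cn2[C@@H]1O[C@H](CO)[C@@H](O)[C@H]1O` gives 450 nM
- Compound 2 `C#Cc1cn([C@@H]2O[C@H](CO)[C@@H](O)[C@H]2O)c2ncnc(N(C)C)c12` gives 110 nM
- Compound 3 `Nc1nc(N)c2c(-c3cccs3)cn([C@@H]3O[C@H](CO)[C@@H](O)[C@H]3O)c2n1` gives > 20000 nM

The value of compound 3 is a limit of the assay and not a number. Compound 3 therefore stands at the limit of > 20000 nM in this assay, at which 1 of the 3 values shown sits, while compound 1 and compound 2 both have numerical readings. For the measured compounds named here, no two measured compounds differ in one place, so no measured step bears directly on the next change.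

Compound 4 `Nc1nc(N)c2c(-c3cc4ccccc4o3)cn([C@@H]3O[C@H](CO)[C@@H](O)[C@H]3O)c2n1` carries 1-benzofuran-2-yl in place of thiophen-2-yl on an aromatic carbon of the shared core: 1-benzofuran-2-yl in place of thiophen-2-yl on an aromatic carbon. Going by the values given here, the only measured compound with this core apart from that group is compound 3 at > 20000 nM, so the expectation starts from this limit. No change beyond the scatter is expected in this assay, and a second limit reading is the likeliest outcome. The expected size of the change is a number no higher from compound 3 to compound 4 (the limit leaves the size open). For compound 4 the estimate is 20000 nM. The expected range for compound 4 runs from 7000 nM to 40000 nM.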

Compound 4, half-maximal inhibitory concentration: 18600 nM
For compound 4 the middle estimate is 1.1-fold (0.03 log units) above the measured one, within the range that was stated.
By their numbers in this assay, from the lowest: compound 2; then compound 1; then compound 4. At a limit, above all of these: compound 3.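

In this assay, 1-benzofuran-2-yl in place of thiophen-2-yl on this aromatic carbon gives an at least 1.0-fold lower number from compound 3 to compound 4 (0.03 log units; that floor lies within the scatter). Compound 3 stands at a limit of the assay and not at a number: the limit of > 20000 nM in this assay, at which 1 of the 4 values shown sits.

On these data alone, compound 4 gives 18600 nM, so this position on the shared core now has a numerical reading, but the true size of the step stays open, and the added six-membered aromatic ring of carbon only cannot be credited with a change beyond the scatter.

As far as these compounds go, it remains open how a much smaller group on this aromatic carbon, such as methyl or an amine, would read on the shared core. Compound 1 and compound 2 differ from compound 4 in more than one place, so they give no comparison for this change.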